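A few compounds are considered here, and "the series" means these few. Any claim that something is new, unique, unknown or untested is made for them only; others in the source may bear on it.

Working notes on the series. Compound 1 `COc1cc2oc(-c3cccc(C(=O)Nc4ccc(C)cc4)c3)cc(=O)c2c(OC)c1OC` and compound 2 `COc1cc2oc(-c3cccc(NC(=O)c4cccc(Br)c4)c3)cc(=O)c2c(O)c1OC` differ in more than one place, yet both sit at the same level: in a functional assay on RPMI-8226 cells (Homo sapiens) for inhibition, read by sulforhodamine B assay, tested at 10 uM (a lower number here means less inhibition, a higher number more inhibition at the concentration tested (going by the name of the read-out)), compound 1 gives 82.6%, and in this assay compound 2 gives 82.6%, level with compound 1 at the digits printed. Compound 3 `COc1cc2oc(-c3cccc(C(=O)Nc4ccc(C)cc4)c3)cc(=O)c2c(O)c1OC` carries the change ((4-methylphenyl)carbamoyl in place of ((3-bromophenyl)carbonyl)amino on an aromatic carbon). Going by the values given here, with no single-point step measured in the set, the step from compound 2 to compound 3 is expected to stay within the scatter, estimated as a number 2.6 percentage points lower from compound 2 to compound 3 (within the scatter). Compound 3 is expected to give about 80%, with a range of 60% to 92%.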

Compound 3, a percentage reported as inhibition, at one concentration (the size of the read-out at that concentration, not a potency): 82.6%
Estimate against measurement, compound 3: 2.6 percentage points below, within the range that was stated.
By their numbers in this assay, from the lowest: compounds 1, 2 and 3 (each within the scatter of the next).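

In this assay, (4-methylphenyl)carbamoyl in place of ((3-bromophenyl)carbonyl)amino on this aromatic carbon gives a single-place comparison (no change at the digits printed from compound 2 to compound 3 (within the scatter)), so either group holds the level here at the concentration tested. Hydrogen in place of methyl on an oxygen on an aromatic ring likewise leaves the read-out level (no change at the digits printed from compound 1 to compound 3 (within the scatter)). Nothing at hand explains either result.

Open, from the compounds shown here alone, is whether a carboxylic acid or an amine at this aromatic carbon, or an ethyl group on that oxygen, would hold the same level. A single-concentration read-out also leaves potency open.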